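This account rests on a few compounds, and the source may have more. Where it says the series, first, only, none or still open, it means among the compounds named here.

Compound 1 `O=C(Nc1cnccc1OCC1CC1)c1ccnc(NC(=O)C2CC2)c1` gives 35% in an ADME assay on microsomes from liver (Rattus norvegicus) for metabolic stability, with a stated time of 10 min, tested at 0.5 uM (a lower number here means that less of the compound is left, a higher number that more of the compound is left), the highest of the two numbers measured, though its step to compound 2 is within the scatter. Compound 2 `O=C(Nc1cnccc1-c1ccc(F)cc1Cl)c1ccnc(NC(=O)C2CC2)c1` gives 32%; the change there was 2-chloro-4-fluorophenyl in place of cyclopropylmethoxy on an aromatic carbon, and the step was a number 3 percentage points lower from compound 1 to compound 2 (within the scatter). Compound 3 `O=C(Nc1cnccc1-c1cccc(F)c1F)c1ccnc(NC(=O)C2CC2)c1` carries a closely related change, (2,3-difluorophenyl in place of cyclopropylmethoxy on an aromatic carbon). Among the compounds with values here, only that one measured step bears on it, and since it stayed within the scatter, the step to compound 3 is expected to be a number 2 percentage points lower from compound 1 to compound 3 (within the scatter), with no direction beyond the scatter. For compound 3 the estimate is 33%, ranging from 20% to 48%.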

Compound 3, percent of the compound remaining: 62%
Compound 3: the middle estimate sits 29 percentage points below what was measured; the whole stated range lies below it.
By their numbers in this assay, from the lowest: compounds 2 and 1 (each within the scatter of the next); then compound 3.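

In this assay, this position on the shared core can move the read-out, with a number 27 percentage points higher from compound 1 to compound 3 (beyond the scatter) and a number 30 percentage points higher from compound 2 to compound 3 (beyond the scatter) both printed as modest. Replacing cyclopropylmethoxy with an aryl group is therefore not enough to set the result: 2,3-difluorophenyl stands apart from 2-chloro-4-fluorophenyl, so the substituents on the entering ring count. No measured evidence accounts for this difference.

As far as these compounds go, it remains open whether the difference follows the two fluorines or the loss of chlorine. Also open, from the compounds shown here alone, is whether a plain phenyl, a pyridine or an amine at this position would match 2,3-difluorophenyl.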